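Methoxy added to compound 2: an expected limit

The compounds below may be only part of what the source reports. "The series", "measured", "known", "first", "only" and "open" are said of these compounds alone.

Among the measured compounds shown here, the three measured members, compound 1 `COc1ccc(CNc2nc([SeH])nc3ccccc23)cc1`, compound 2 `Sc1nc(NCc2ccccc2)c2ccccc2n1` and compound 3 `CSc1nc(NCc2ccccc2)c2ccccc2n1`, have all been run in a functional assay on CCRF-CEM cells (Homo sapiens) for cytotoxicity, read by MTT assay, with a stated time of 72 h; on this read-out lower numbers stand for stronger inhibition of growth and higher numbers for weaker inhibition of growth. Compound 1 reaches only the limit of > 100000 nM. Compound 2 likewise gives only the limit of > 100000 nM. Compound 3 also stops at the limit of > 100000 nM. For the measured compounds named here, the one single-point step among them, a step that the two limits leave unreadable from compound 2 to compound 3, is accordingly not readable, and compound 2 stands at a limit rather than at a number.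

Compound 4 `COc1ccc(CNc2nc(S)nc3ccccc23)cc1`, not yet measured, differs from compound 2 by methoxy in place of hydrogen on an aromatic carbon. Going by the values given here, no measured step isolates this change, and compound 1 set beside compound 2 offers no readable comparison either, given (the limit of > 100000 nM in this assay, at which 3 of the 3 values shown sit). The expectation in this assay is therefore no step beyond the scatter, with compound 4 expected to remain at the limit. The estimated step that the limit leaves unreadable from compound 2 to compound 4 is taken as essentially flat. Compound 4 is thus expected at 200000 nM, within a range from 60000 nM to 600000 nM, and most likely reported only as a limit.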

Compound 4, concentration for total growth inhibition: 41000 nM
Compound 4: middle estimate off by 4.9-fold (0.69 log units), on the high side; the measured number lies below the stated range.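

In this assay, methoxy in place of hydrogen on an aromatic carbon, para to a large group, gives an at least 2.4-fold lower number from compound 2 to compound 4 (0.38 log units; beyond the scatter). Methoxy alone does not secure a number, however: compound 1 carries it too and stays at a limit, while one sulfur atom in place of one selenium atom gives an at least 2.4-fold lower number from compound 1 to compound 4 (0.38 log units; beyond the scatter). Compound 4 is the only member of the series with a number rather than a limit, so both steps give only a minimum size: the limit of > 100000 nM in this assay, at which 3 of the 4 values shown sit.

On these data alone, the full size of both steps remains open, and the step from compound 2 to compound 3 cannot be read. Also open, as far as these compounds go, is whether hydroxyl, chlorine or an amine at the same place would give a number, and whether methoxy holds up with a methyl on the sulfur.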